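Notes on the nitrophenyl change from compound 3 to compound 4

This account rests on a few compounds, and the source may have more. Where it says the series, first, only, none or still open, it means among the compounds named here.

Measured so far in a functional assay on HeLa cells (Homo sapiens) for antiproliferative activity, read by MTT assay, with a stated time of 48 h; on this read-out higher numbers stand for weaker inhibition and lower numbers for stronger inhibition
compound 1 `O=[N+]([O-])c1cccc(-c2nn(-c3ccccc3)cc2C(Nc2nc3ccccc3s2)c2c(O)ccc3ccccc23)c1` gives 8220 nM
compound 2 `Cc1ccc2nc(NC(c3cn(-c4ccccc4)nc3-c3cccc([N+](=O)[O-])c3)c3c(O)ccc4ccccc34)sc2c1` gives 7360 nM
compound 3 `COc1ccc2nc(NC(c3cn(-c4ccccc4)nc3-c3ccc([N+](=O)[O-])cc3)c3c(O)ccc4ccccc34)sc2c1` gives 5540 nM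

Compound 3 stands level with compound 1 and compound 2, as all three values lie within the scatter of one another. Compound 4 `COc1ccc2nc(NC(c3cn(-c4ccccc4)nc3-c3cccc([N+](=O)[O-])c3)c3c(O)ccc4ccccc34)sc2c1` carries 3-nitrophenyl in place of 4-nitrophenyl on an aromatic carbon. Within the data shown here, the only measured step is a 1.1-fold lower number from compound 1 to compound 2 (0.05 log units; within the scatter) and it concerns methyl in place of hydrogen, so it bears only indirectly. Among the measured compounds shown here, no measured step moves the nitro group. Compound 1 and compound 2 already carry 3-nitrophenyl, and their values sit within the scatter of compound 3. In this assay no shift beyond the scatter is expected in either direction, with a 1.2-fold higher number from compound 3 to compound 4 (0.07 log units; within the scatter) as the expected step. Compound 4 is estimated at 6500 nM with an expected range from 3500 nM to 12000 nM in this series.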

Compound 4, half-maximal inhibitory concentration: 6140 nM
The estimate for compound 4 lay 1.1-fold (0.02 log units) above the measured number; the measured number falls inside the stated range.
By their numbers in this assay, from the lowest: compounds 3, 4, 2 and 1 (each within the scatter of the next).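

In this assay, among these compounds, 3-nitrophenyl and 4-nitrophenyl on this aromatic carbon cannot be told apart (a 1.1-fold higher number from compound 3 to compound 4 (0.04 log units; within the scatter)), the first direct reading of this exchange. With 3-nitrophenyl in place, methoxy on the core also stands level with methyl (a 1.2-fold lower number from compound 2 to compound 4 (0.08 log units; within the scatter)) and with hydrogen (a 1.3-fold lower number from compound 1 to compound 4 (0.13 log units; within the scatter)). Nothing available on these compounds offers an explanation for these readings.

On these data alone, whether a phenyl ring carrying an amine or a carboxylic acid instead of the nitro group would give a step beyond the scatter remains open. So does the outcome of a longer chain on the core in place of methoxy.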